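The compounds below may be only part of what the source reports. "The series", "measured", "known", "first", "only" and "open" are said of these compounds alone.

Measured compounds in an assay on HEK293 cells for displacement of a labelled ligand from Melanocortin receptor 4 (Homo sapiens); on this read-out higher numbers stand for weaker inhibition and lower numbers for stronger inhibition:
- compound 1 `CC(C)C[C@H](N)c1cc(C(F)(F)F)ccc1N1CCN(C(=O)C(C)Cc2ccc(Cl)c(Cl)c2)CC1`, 120 nM; 1600 nM (2 entries)
- compound 2 `CC(C)C[C@H](N)c1cc(C(F)(F)F)ccc1N1CCN(C(=O)CC(C)C(=O)c2ccc(Cl)cc2)CC1`, 1100 nM

Compound 1 has two entries, (the several entries of compound 1 in this assay, 120 nM; 1600 nM (2 entries)), which are themselves spread apart, so the shared core tolerates some variation at the amide side chain. Compound 2 stands on the only number shown for it in this assay; a further entry for compound 2 carries no single number. For the measured compounds named here, compound 2 and compound 1 are not separated by a single structural step, so no measured step between them is available.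

Compound 3 `CC(C)C[C@H](N)c1cc(C(F)(F)F)ccc1N1CCN(C(=O)CCNC2CCCCC2)CC1` is the next member, not yet measured. The change from compound 2 is (cyclohexylamino)methyl in place of 1-((4-chlorophenyl)carbonyl)ethyl on a saturated chain carbon bound to a carbonyl carbon, the same difference, cut one bond further out, reads 2-((4-chlorophenyl)carbonyl)propyl to 2-(cyclohexylamino)ethyl. Going by the values given here, no measured step covers a change of this kind, so the expected step of a 1.8-fold higher number from compound 2 to compound 3 (0.26 log units; within the scatter) from compound 2 to compound 3 is set only modestly toward weaker inhibition, with a wide range. For compound 3 in this assay the estimate is 2000 nM, expected between 400 nM and 10000 nM.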

Compound 3, inhibition constant: 4800 nM
The estimate for compound 3 lay 2.4-fold (0.38 log units) below the measured number; measured number inside the range.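

In this assay, (cyclohexylamino)methyl in place of 1-((4-chlorophenyl)carbonyl)ethyl on a saturated chain carbon bound to a carbonyl carbon gives a 4.4-fold higher number from compound 2 to compound 3 (0.64 log units; beyond the scatter). For the compounds shown here, this is the first step read at this position, and it shows that the position does respond to the side chain: the change replaces the six-membered aromatic ring with a non-aromatic one, removes the chlorine and the side-chain carbonyl, adds a nitrogen and a hydrogen-bond donor, and moves the number toward weaker inhibition. The step rests on single numbers, and entries for one compound in this series can lie far apart: the several entries of compound 1 in this assay, 120 nM; 1600 nM (2 entries).

Which part of the exchange carries the step remains open. A (4-chlorophenylamino)methyl group at the same place would keep the amine and the chlorophenyl ring together and test the ring on its own.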